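The source may hold more compounds than are shown below. What is called first, only, known or untested is meant among the compounds shown, and "the series" means these compounds.

Within the data shown here, in a toxicity assay on cells (Erythrocyte, Homo sapiens) for cytotoxicity, read by hemolysis (on this read-out lower numbers stand for an effect already at smaller amounts and higher numbers for an effect only at larger amounts of compound), compound 2 `CCCCCCCCCCCC(=O)NCc1ccc(C(=O)N[C@H](C(=O)O)[C@@H](C)CC)cc1` gives 400 ug/mL, the only actual number available so far. Compound 1 `CCCCCCCCCC(=O)NCc1ccc(C(=O)N[C@H](C(=O)O)[C@@H](C)CC)cc1` gives > 1000 ug/mL, which is a limit of the assay and not a number. Among the measured compounds shown here, the single measured step, an at least 2.5-fold lower number from compound 1 to compound 2 (0.39 log units; beyond the scatter), lies beyond the scatter and comes with ethyl in place of hydrogen on a saturated chain carbon. Compound 3 `CC/C=C/CC(=O)NCc1ccc(C(=O)N[C@H](C(=O)O)[C@@H](C)CC)cc1` departs from compound 2 through (but-1-en-1-yl in place of decyl on a saturated chain carbon bound to a carbonyl carbon). This change also concerns the chain, but it runs the opposite way, since the decyl leaves and the smaller but-1-en-1-yl enters. The evidence is thin, resting on one step whose size is itself bounded by a limit. Still, the step of an at least 2.5-fold lower number from compound 1 to compound 2 (0.39 log units; beyond the scatter) points towards a higher number on removing chain carbons, so a move beyond the scatter is expected here. The expected change is a 5.0-fold higher number from compound 2 to compound 3 (0.70 log units; beyond the scatter). The reading may well stop at the limit already met by one of the two tested compounds, (the limit of > 1000 ug/mL in this assay, at which 1 of the 2 values shown sits). For compound 3 the estimated value is 2000 ug/mL, with an expected range of 1000 ug/mL to 5000 ug/mL.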

Compound 3, half-maximal effective concentration: > 1500 ug/mL
Compound 3 ended at the assay's limit (the forecaster's own chance of this, stated with the estimate: 90%); the middle value lies beyond the limit too.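

In this assay, but-1-en-1-yl in place of decyl on a saturated chain carbon bound to a carbonyl carbon gives an at least 3.7-fold higher number from compound 2 to compound 3 (0.57 log units; beyond the scatter), which is the first step shown in which this chain loses carbons rather than gains them, and the first to bring in a double bond. Together with the earlier step, it shows the number moving in the opposite direction when the chain is shortened, although only these three compounds stand behind that pattern and none goes against it. The value of compound 3 is a limit of the assay and not a number, so the true size of the step stays open, and the step between compound 1 and compound 3 cannot be read: the limit of > 1500 ug/mL in this assay, at which 1 of the 3 values shown sits.

The change removes carbons and adds a double bond in one move, so the compounds shown do not tell which of the two carries the step, and a saturated butyl chain in the same place would separate them. On these data alone, how far the number falls with a chain longer than decyl, or how an amine or a carboxylic acid at the chain end would read, also remains open.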